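The source may report more compounds than this note shows. Statements on the series, on what has been measured and on what is new or still open speak of the compounds shown alone.

Among the compounds with values here, compound 2 `COc1cccc(CNCCCNc2ccnc3cc(-c4cccc5ccccc45)ccc23)c1O` gives 32000 nM in a physicochemical assay for solubility, with a stated time of 18 h, at pH 7.4 (on this read-out lower numbers stand for lower solubility and higher numbers for higher solubility), the highest of the two numbers measured so far; compound 1 `COc1cccc(CNCCCNc2ccnc3cc(Cc4ccc(F)cc4)ccc23)c1O` gives 4200 nM. Compound 3 `COc1cccc(CNCCCNc2ccnc3cc(C4CCCCC4)ccc23)c1O` differs from compound 2 by a single change: cyclohexyl in place of naphthalen-1-yl on an aromatic carbon. Within the data shown here, the one measured step that bears on it, a 7.6-fold higher number from compound 1 to compound 2 (0.88 log units; beyond the scatter), shows that exchanging the group here can move solubility well beyond the scatter, yet no measured compound carries a cyclohexyl, so the direction remains uncertain. A modest fall is expected, a 3.2-fold lower number from compound 2 to compound 3 (0.51 log units; beyond the scatter). Compound 3 is therefore estimated at 10000 nM, within a range of 3000 nM to 40000 nM.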

Compound 3, solubility: 4200 nM
Compound 3: the middle estimate sits 2.4-fold (0.38 log units) above what was measured, and the stated range covers the measured number.
By their numbers in this assay, from the lowest: compounds 1 and 3 (each within the scatter of the next); then compound 2.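

In this assay, cyclohexyl in place of naphthalen-1-yl gives a 7.6-fold lower number from compound 2 to compound 3 (0.88 log units; beyond the scatter), so the higher number of compound 2 does not carry over to this six-membered non-aromatic ring. Cyclohexyl in place of 4-fluorobenzyl gives no change at the digits printed from compound 1 to compound 3 (within the scatter), so among these three groups only naphthalen-1-yl stands apart. Nothing measured here gives a reason for these numbers. The compounds shown leave open whether a single phenyl ring on this carbon would stand with compound 2 or with compounds 1 and 3. They also leave open how a group carrying an amine or a carboxylic acid would read in this assay.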